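This account rests on a few compounds, and the source may have more. Where it says the series, first, only, none or still open, it means among the compounds named here.

In a functional assay, with a stated time of 90 s (a higher number here means a weaker inhibitor, a lower number a stronger inhibitor), three compounds sharing one core have been measured, and they differ only in the group on one aromatic carbon. Compound 1 (`Cc1nc2c3ccccc3ccc2c2nc3c(ccc4ccccc43)c(-c3cccc([N+](=O)[O-])c3)c12`) with 3-nitrophenyl gives 157 ug/mL as its value, compound 2 (`Cc1nc2c3ccccc3ccc2c2nc3c(ccc4ccccc43)c(-c3nccnc3N)c12`) with 3-aminopyrazin-2-yl gives 134 ug/mL as its value, and compound 3 (`Cc1nc2c3ccccc3ccc2c2nc3c(ccc4ccccc43)c(-c3cccc4ccccc34)c12`) with naphthalen-1-yl gives 179 ug/mL as its value. Compound 3 thus stands level with both of the others, since its gaps to them lie within the scatter.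

Compound 4 (`Cc1nc2c3ccccc3ccc2c2nc3c(ccc4ccccc43)c(-c3ccccc3S)c12`) has not yet been measured. It carries 2-sulfanylphenyl in place of naphthalen-1-yl on an aromatic carbon, opposite the ring nitrogen (2-sulfanylphenyl in place of naphthalen-1-yl on an aromatic carbon). The three measured exchanges at that carbon are all small: a 1.2-fold lower number from compound 1 to compound 2 (0.07 log units; within the scatter) in one case, a 1.1-fold higher number from compound 1 to compound 3 (0.06 log units; within the scatter) in another and a 1.3-fold higher number from compound 2 to compound 3 (0.13 log units; within the scatter) in the third, each within the scatter. Within the data shown here, no measured compound carries a sulfanyl group, so that part of the change remains untested. No step beyond the scatter is therefore expected in this assay in either direction. The expected size is a 1.2-fold lower number from compound 3 to compound 4 (0.08 log units; within the scatter) on this reasoning. Compound 4 is expected at 150 ug/mL as an estimate, with a likely range from 95 ug/mL to 235 ug/mL in repeated measurements.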

Compound 4, half-maximal inhibitory concentration: 158 ug/mL
Compound 4: middle estimate off by 1.1-fold (0.02 log units), on the low side; low and high end bracket the measured number.
By their numbers in this assay, from the lowest: compounds 2, 1, 4 and 3 (each within the scatter of the next).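

In this assay, among these compounds, the first sulfur-bearing group at this carbon, opposite the ring nitrogen, gives a 1.1-fold lower number from compound 3 to compound 4 (0.05 log units; within the scatter), so exchanging the two carbon rings of naphthalen-1-yl for the single ring of 2-sulfanylphenyl, with its hydrogen-bond donor and acceptor, leaves the number level. The comparisons with the other two groups read the same way (a 1.2-fold higher number from compound 2 to compound 4 (0.07 log units; within the scatter); a 1.0-fold higher number from compound 1 to compound 4 (0.00 log units; within the scatter)), so compounds 1, 2, 3 and 4 all stand level here, whether the group on this carbon carries a nitro group, an amino group on a pyrazine, a second fused ring or a sulfanyl group. Nothing available gives a reason for this flatness.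

As far as these compounds go, all four groups attach through an aromatic ring, so it remains open whether a group of another kind on this carbon, such as a short alkyl chain, a free amine or a carboxylic acid, would also stand level with them. From the compounds shown here alone, it is also open whether the sulfanyl group matters at all, which a plain phenyl, a 2-hydroxyphenyl or a 4-sulfanylphenyl would help to show.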